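Hydrazone urea series: cytotoxicity notes on a rearranged phenol

This account rests on a few compounds, and the source may have more. Where it says the series, first, only, none or still open, it means among the compounds named here.

The series shares one core, seen in compound 1 `COc1ccc(OC)c(/C=N/NC(=O)Nc2ccc(Oc3ccnc(-c4nncn4CCN(C)C)c3)c(F)c2)c1`, compound 2 `CN(C)CCn1cnnc1-c1cc(Oc2ccc(NC(=O)N/N=C/c3ccc(O)c(Br)c3)cc2F)ccn1` and compound 3 `COc1ccc(/C=N/NC(=O)Nc2ccc(Oc3ccnc(-c4nncn4CCN(C)C)c3)c(F)c2)cc1O`, with the aryl group on the hydrazone carbon as the varied part. For the measured compounds named here, in an ADME assay on WI-38 cells (Homo sapiens) for cytotoxicity, read by MTT assay, with a stated time of 72 h (on this read-out higher numbers stand for weaker inhibition and lower numbers for stronger inhibition), compound 2 gives 5560 nM, the only number available in the set. For compound 1 the entry in this assay stands as "not determined" (no result reported), and for compound 3 it stands as "not determined" (no result reported), so compound 3 has no single number to stand on; one further member of the set is in the same position. Going by the values given here, no step between measured compounds is available, and nothing ties compound 3 to compound 2 beyond the shared core.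

Compound 4 `COc1cc(/C=N/NC(=O)Nc2ccc(Oc3ccnc(-c4nncn4CCN(C)C)c3)c(F)c2)ccc1O` differs from compound 3 in one place: 4-hydroxy-3-methoxyphenyl in place of 3-hydroxy-4-methoxyphenyl on a carbon with a double bond to nitrogen. Among the compounds with values here, with no measured step to lean on, any shift in this assay is expected to stay within the scatter, in no settled direction. Compound 4 is accordingly estimated to give 6000 nM in this assay, with a range from 2000 nM to 25000 nM, the middle taken near the value of compound 2 5560 nM as the only anchor in the set.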

Compound 4, half-maximal inhibitory concentration: 5320 nM
For compound 4 the middle estimate is 1.1-fold (0.05 log units) above the measured one; measured number inside the range.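

In this assay the series now has one readable step, a 1.0-fold lower number from compound 2 to compound 4 (0.02 log units; within the scatter), for methoxy in place of bromo on an aromatic carbon, so at this position on the aryl group the exchange stays within the scatter for this one pair. The exchange of 3-hydroxy-4-methoxyphenyl for 4-hydroxy-3-methoxyphenyl cannot itself be read, as compound 3 has no single number. No measurement in hand offers a reason for this result.

Going by these compounds, whether the same flat picture holds for a larger change at this position, such as an amine, a carboxylic acid or a longer alkoxy chain in place of methoxy, remains open. Also open, on these data alone, is what the hydroxy group contributes, as both compounds with numbers carry it.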